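Replacing the Fluorinated Amine Chains of Compound 1

This account rests on a few compounds, and the source may have more. Where it says the series, first, only, none or still open, it means among the compounds named here.

Compound 1 `Cc1cc(C)c(-n2c(Cl)cn3c(CN(CCC(F)(F)F)CC4CC4)c(C(F)(F)F)nc23)c(C)c1` was tested in an assay on cells for displacement of a labelled ligand from corticotropin-releasing factor receptor 1 (Homo sapiens), with a stated time of 100 min (a higher number here means a weaker inhibitor, a lower number a stronger inhibitor), where compound 1 gives 16 nM. Among the three measured compounds this is the second highest number. Compound 2 `CCCN(CCC(F)(F)F)Cc1c(C(F)(F)F)nc2n(-c3c(C)cc(C)cc3C)c(Cl)cn12` gives 12 nM, and the pair shows a 1.3-fold lower number from compound 1 to compound 2 (0.12 log units; within the scatter). Compound 3 `CCCCN(CC)Cc1c(C(F)(F)F)nc2n(-c3c(C)cc(C)cc3C)c(Cl)cn12` gives 78 nM, a step of a 4.9-fold higher number from compound 1 to compound 3 (0.69 log units; beyond the scatter), and the comparison from the second compound shows a 6.5-fold higher number from compound 2 to compound 3 (0.81 log units; beyond the scatter).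

Compound 4 `C=CCN(CCC)Cc1c(C(F)(F)F)nc2n(-c3c(C)cc(C)cc3C)c(Cl)cn12` has not yet been measured. It differs from compound 1 by allyl(propyl)amino in place of (cyclopropylmethyl)(3,3,3-trifluoropropyl)amino on a saturated chain carbon bound to an aromatic carbon. The measured steps that bear on this change are a 4.9-fold higher number from compound 1 to compound 3 (0.69 log units; beyond the scatter) and a 6.5-fold higher number from compound 2 to compound 3 (0.81 log units; beyond the scatter), since in both of them an amine carrying a 3,3,3-trifluoropropyl chain was exchanged for one carrying only plain chains, which is also what happens in going to compound 4. Both of those steps were modest and in the direction of a higher number, so a step of similar size and direction is expected here, beyond the scatter but not large. Compound 4 is therefore expected to give 60 nM in this assay, with a range from 25 nM to 150 nM. This estimate corresponds to an expected step of a 3.8-fold higher number from compound 1 to compound 4 (0.57 log units; beyond the scatter).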

Compound 4, inhibition constant: 4.5 nM
Compound 4: middle estimate off by 13-fold (1.12 log units), on the high side; the measured number lies below the stated range.
By their numbers in this assay, from the lowest: compound 4; then compounds 2 and 1 (each within the scatter of the next); then compound 3.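

In this assay, the step to compound 4 shows that the amine on this saturated chain carbon does not need a 3,3,3-trifluoropropyl chain to give a low number: allyl(propyl)amino, which has neither fluorine nor a ring, gives a 3.6-fold lower number from compound 1 to compound 4 (0.55 log units; beyond the scatter). Among the compounds shown here, compound 3 had been the only compound with plain chains, and the result shows that such amines are not alike, since exchanging butyl(ethyl)amino for allyl(propyl)amino gives a 17-fold lower number from compound 3 to compound 4 (1.24 log units; beyond the scatter). For the compounds shown here, the closest comparison keeps the propyl chain and changes only the other one, with vinyl in place of 2,2,2-trifluoroethyl on a saturated chain carbon bound to an amine nitrogen, and it gives a 2.7-fold lower number from compound 2 to compound 4 (0.43 log units; beyond the scatter), which reverses the direction suggested by the earlier steps.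

No measurement is available that accounts for these differences in binding. As far as these compounds go, it remains open whether the double bond of the allyl chain matters or whether chain length alone would do, and a dipropylamino or a diallylamino group on the same carbon would separate these two readings.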